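Halogen Pattern on the Amide Aryl Ring: Compound 4

The source may hold more compounds than are shown below. What is called first, only, known or untested is meant among the compounds shown, and "the series" means these compounds.

Compound 1 `O=C(CSc1nc(Nc2ccccc2)c2ccccc2n1)Nc1ccccc1F`: 10700 nM
Compound 2 `O=C(CSc1nc(Nc2ccccc2)c2ccccc2n1)Nc1cccc(Br)c1`: 9620 nM
Compound 3 `O=C(CSc1nc(Nc2ccccc2)c2ccccc2n1)Nc1ccc(Cl)cc1`: 40400 nM

In a functional assay on MGC-803 cells (Homo sapiens) for inhibition, read by MTT assay, with a stated time of 72 h (on this read-out lower numbers stand for stronger inhibition and higher numbers for weaker inhibition), compound 3 gives 40400 nM, the highest number among the three measured compounds. The nearest is compound 1 at 10700 nM, with a 3.8-fold higher number from compound 1 to compound 3 (0.58 log units; beyond the scatter); the furthest is compound 2 at 9620 nM, with a 4.2-fold higher number from compound 2 to compound 3 (0.62 log units; beyond the scatter). The pair of compounds 1 and 2 sits together, with a 1.1-fold lower number from compound 1 to compound 2 (0.05 log units; within the scatter).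

Compound 4 `O=C(CSc1nc(Nc2ccccc2)c2ccccc2n1)Nc1ccc(F)c(Cl)c1` carries 3-chloro-4-fluorophenyl in place of 4-chlorophenyl on an amide-type nitrogen. For the measured compounds named here, the steps that bear on this change are those that alter the aryl group on the amide-type nitrogen: compound 1 to compound 3 and compound 2 to compound 3, both modest and both beyond the scatter, with the 4-chlorophenyl compound giving the higher number. A second halogen on this ring is a change of the same kind, so a modest step in this assay is expected, most likely toward a lower number, though the direction is uncertain. Compound 4 is expected to give about 20000 nM, with a range from 7000 nM to 55000 nM, meaning a 2.0-fold lower number from compound 3 to compound 4 (0.31 log units; beyond the scatter).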

Compound 4, half-maximal inhibitory concentration: 20900 nM
Compound 4: middle estimate off by 1.0-fold (0.02 log units), on the low side; the measured number falls inside the stated range.
By their numbers in this assay, from the lowest: compounds 2, 1, 4 and 3 (each within the scatter of the next, the first and the last beyond it).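

Placing 3-chloro-4-fluorophenyl in place of 4-chlorophenyl on the amide-type nitrogen gives, in this assay, a 1.9-fold lower number from compound 3 to compound 4 (0.29 log units; within the scatter), so this group with two halogens cannot be told apart from the 4-chlorophenyl group of compound 3. For the compounds shown here, the step of a 2.0-fold higher number from compound 1 to compound 4 (0.29 log units; within the scatter) also stays within the scatter, whereas a 2.2-fold higher number from compound 2 to compound 4 (0.34 log units; beyond the scatter) is modest and lies beyond it, so compound 4 fills the gap that the earlier compounds left and the halogen-bearing groups now form a continuous spread rather than two separate sets. Nothing available explains these differences at this position.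

All four aryl groups shown here carry only halogens. As far as these compounds go, what a methoxy group, an amine or a carboxylic acid on this ring would give remains open, as does whether any such group could move the number well outside this narrow spread.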